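Lipophilicity of a Fused Pyrimidine Series: Anilino for Phenylcarbamoyl

A few compounds are considered here, and "the series" means these few. Any claim that something is new, unique, unknown or untested is made for them only; others in the source may bear on it.

Measured compounds:
compound 1 `Cc1cc(-c2cnc(NCc3c(F)ccc4c3CCO4)c3cn[nH]c(=O)c23)n(C)n1` gives 3
compound 2 `O=C(Nc1ccccc1)c1cnc(NCc2c(F)ccc3c2CCO3)n2cnnc12` gives 4.1
compound 3 `CN(C)Cc1ccc2c(c1)CN(c1cnc(NCc3c(F)ccc4c3CCO4)c3cn[nH]c(=O)c13)C2=O` gives 2.2

In a physicochemical assay for lipophilicity, using the shake flask method, in phosphate buffer, measured as octanol-water partition, with a stated time of 30 min, at pH 7.4 (a higher number here means a more lipophilic compound, a lower number a more polar compound), compound 2 stands highest of the three, with compound 1 lying closer to it and compound 3 furthest away, both beyond the scatter. Compound 4 `Fc1ccc2c(c1CNc1ncc(Nc3ccccc3)c3nncn13)CCO2` has not yet been measured. It differs from compound 2 in one place: anilino in place of phenylcarbamoyl on an aromatic carbon. Within the data shown here, no single-change pair with known values exists among the measured compounds, so the expected step from compound 2 to compound 4 rests only on the nature of the change. The group that leaves carries a carbonyl that the entering anilino lacks, and the expected step of a number 0.50 log units higher from compound 2 to compound 4 (beyond the scatter) is a modest rise, possibly no more than the scatter. Compound 4 is therefore estimated at 4.6, with a range from 4 to 5.2.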

Compound 4, distribution coefficient: 3.3
The estimate for compound 4 lay 1.30 log units above the measured number; the whole stated range lies above it.
By their numbers in this assay, from the lowest: compound 3; then compounds 1 and 4 (each within the scatter of the next); then compound 2.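

Among these compounds, measured in this assay the exchange of phenylcarbamoyl for anilino on an aromatic carbon gives a number 0.80 log units lower from compound 2 to compound 4 (beyond the scatter) and is the only single change in these compounds that can be read. The group that leaves is the larger one and carries the carbonyl, yet the number falls once it is gone. Nothing measured here accounts for this step.

The compounds shown leave open whether the step would hold on another core. They also leave open how a carboxylic acid or a morpholine at this aromatic carbon would read in this assay.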